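The source may report more compounds than this note shows. Statements on the series, on what has been measured and on what is new or still open speak of the compounds shown alone.

The compounds measured in a functional assay on MGC-803 cells (Homo sapiens) for inhibition, read by MTT assay, with a stated time of 72 h; on this read-out higher numbers stand for weaker inhibition and lower numbers for stronger inhibition:

- compound 1, `Cc1cc(Nc2cc(-c3ccccc3)[nH]n2)n2nc(SCc3ccc([N+](=O)[O-])cc3)nc2n1`; in this assay compound 1 gives 4250 nM
- compound 2, `Cc1cc(Nc2cc(-c3ccccc3)[nH]n2)n2nc(SCc3csc4ccccc34)nc2n1`; in this assay compound 2 gives 2280 nM
- compound 3, `Cc1cc(Nc2cc(-c3ccccc3)[nH]n2)n2nc(SCc3ccc(C(F)(F)F)cc3)nc2n1`; in this assay compound 3 gives 3520 nM

All three numbers lie close together. Among the compounds with values here, the step of a 1.9-fold lower number from compound 1 to compound 2 (0.27 log units; within the scatter), the step of a 1.2-fold lower number from compound 1 to compound 3 (0.08 log units; within the scatter) and the step of a 1.5-fold higher number from compound 2 to compound 3 (0.19 log units; within the scatter) each stay within the scatter, so no compound among the three can be set apart from the others. Compound 3 holds the second highest of the three numbers; its nearest neighbour is compound 1 and its furthest is compound 2, and both gaps are within the scatter.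

Compound 4, `COc1ccc(CSc2nc3nc(C)cc(Nc4cc(-c5ccccc5)[nH]n4)n3n2)cc1`, differs from compound 3 in one place: methoxy in place of trifluoromethyl on an aromatic carbon. Within the data shown here, no measured pair exchanges trifluoromethyl for methoxy. The step that comes closest is a 1.2-fold lower number from compound 1 to compound 3 (0.08 log units; within the scatter), where one group on the same aromatic carbon was swapped for another without leaving the scatter; the step of a 1.5-fold higher number from compound 2 to compound 3 (0.19 log units; within the scatter), which changes the whole group on the saturated chain carbon bound to a sulfur, was likewise within the scatter. On this basis the expected step of a 1.0-fold lower number from compound 3 to compound 4 (0.00 log units; within the scatter) is none beyond the scatter. Compound 4 is therefore estimated at 3500 nM, with a range from 1500 nM to 8000 nM.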

Compound 4, half-maximal inhibitory concentration: 3170 nM
Beside the measured number, compound 4's estimate is 1.1-fold (0.04 log units) above it; measured number inside the range.
By their numbers in this assay, from the lowest: compounds 2, 4, 3 and 1 (each within the scatter of the next).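

In this assay, methoxy in place of trifluoromethyl on this aromatic carbon, para to a large group, gives a 1.1-fold lower number from compound 3 to compound 4 (0.05 log units; within the scatter) and thus adds a hydrogen-bond acceptor and removes two heavy atoms without any change that can be read, while methoxy in place of nitro on the same carbon gives a 1.3-fold lower number from compound 1 to compound 4 (0.13 log units; within the scatter) and likewise stays within the scatter. The wider exchange of 1-benzothiophen-3-yl for 4-methoxyphenyl gives a 1.4-fold higher number from compound 2 to compound 4 (0.14 log units; within the scatter) and so does not set compound 2 apart from compound 4, which means that all four compounds, with three different groups at this place and one different aromatic group, still cannot be separated from one another. Nothing measured alongside these numbers offers an explanation for this flat result.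

From the compounds shown here alone, whether an amine or a carboxylic acid on this aromatic carbon would move the number beyond the scatter remains open. Going by these compounds, it is also open whether a longer chain between the sulfur and the aromatic ring, or a change elsewhere on the shared core, would separate any compound from the rest.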